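The source may report more compounds than this note shows. Statements on the series, on what has been measured and on what is new or still open speak of the compounds shown alone.

Measured in a functional assay on COLO 205 cells (Homo sapiens) for inhibition, read by sulforhodamine B assay, with a stated time of 48 h; on this read-out higher numbers stand for weaker inhibition of growth and lower numbers for stronger inhibition of growth:
- compound 1 `O=C(Cc1csc2nc(-c3ccc(Br)cc3)cn12)N/N=C/c1ccccc1O`: 22900 nM
- compound 2 `O=C(Cc1csc2nc(-c3ccc(Br)cc3)cn12)N/N=C/c1ccc(O)cc1`: > 100000 nM

Compound 2 gives only a limit of this assay, > 100000 nM, and no number.

The change to compound 3 `O=C(Cc1csc2nc(-c3ccc(Br)cc3)cn12)N/N=C/c1ccc(Cl)cc1Cl` is 2,4-dichlorophenyl in place of 4-hydroxyphenyl on a carbon with a double bond to nitrogen. Within the data shown here, one measured step bears on it, at the same place: an at least 4.3-fold higher number from compound 1 to compound 2 (0.64 log units; beyond the scatter). That step lies beyond the scatter, so a change at this place can shift the read-out. On that basis, a move to a lower number, meaning stronger inhibition of growth, is expected. The expected step is an at least 2.8-fold lower number from compound 2 to compound 3 (0.45 log units; beyond the scatter). For compound 3 the estimated value is 35000 nM, with an expected range of 12000 nM to 100000 nM.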

Compound 3, concentration for total growth inhibition: > 100000 nM
Compound 3 was reported as a limit; the forecaster's own chance of this, stated with the estimate: 30%; middle value at least 2.8-fold (0.45 log units) from the limit.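

In this assay, the 2,4-dichlorophenyl group shows an at least 4.3-fold higher number from compound 1 to compound 3 (0.64 log units; beyond the scatter). Among these compounds, compound 3 is a limit of the assay, > 100000 nM, so a ring with 0 hydrogen-bond donors at this place yields no number either, and compound 1 remains the only compound with one. The step from compound 2 to compound 3 cannot be read, and the series now sits largely at the ceiling: the limit of > 100000 nM in this assay, at which 2 of the 3 values shown sit.

As far as these compounds go, whether any group at this place gives a lower number than compound 1 stays open. An unsubstituted phenyl or an aminophenyl would test whether the 2-hydroxyphenyl of compound 1 is specifically required.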